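Swapping the benzyl substituent on a piperazine-bearing benzofuran series

The source may report more compounds than this note shows. Statements on the series, on what has been measured and on what is new or still open speak of the compounds shown alone.

Two members of this series have been tested so far. Compound 1, `CCN(CC)c1ccc2cc(C(=O)c3ccc(N4CCN(C(=O)CN5CCN(S(=O)(=O)c6ccc(C#N)cc6)CC5)CC4)cc3)oc2c1`, is reported in a functional assay on A549 cells (Homo sapiens) for cytotoxicity, read by MTT assay, with a stated time of 48 h (on this read-out higher numbers stand for weaker inhibition and lower numbers for stronger inhibition), only as a limit, > 40000 nM, which means the assay gave no number for it. For the measured compounds named here, compound 2, `CCN(CC)c1ccc2cc(C(=O)c3ccc(N4CCN(C(=O)CN5CCN(Cc6ccc(/C=C/C(=O)OC)cc6)CC5)CC4)cc3)oc2c1`, is the sole compound with a measured value in this assay, giving 2810 nM. Going by the values given here, the one other value shown, that of compound 1, is the limit described in the limit of > 40000 nM in this assay, at which 1 of the 2 values shown sits. Compound 3, `CCN(CC)c1ccc2cc(C(=O)c3ccc(N4CCN(C(=O)CN5CCN(Cc6ccc(F)c(F)c6)CC5)CC4)cc3)oc2c1`, has not yet been measured. It differs from compound 2 in one place: 3,4-difluorophenyl in place of 4-(2-(methoxycarbonyl)ethenyl)phenyl on a saturated chain carbon bound to an amine nitrogen in a ring. Among the compounds with values here, with no comparable step between measured compounds to lean on, the author expects a change from compound 2 to compound 3 of a 1.4-fold higher number from compound 2 to compound 3 (0.15 log units; within the scatter), modest and uncertain in direction. The estimate for compound 3 in this assay is 4000 nM, within a range from 1200 nM to 15000 nM.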

Compound 3, half-maximal inhibitory concentration: 5440 nM
For compound 3 the middle estimate is 1.4-fold (0.13 log units) below the measured one, and the stated range covers the measured number.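

In this assay there is a 1.9-fold higher number from compound 2 to compound 3 (0.29 log units; within the scatter) and so, on a saturated chain carbon bound to an amine nitrogen in a ring, 3,4-difluorophenyl and 4-(2-(methoxycarbonyl)ethenyl)phenyl cannot be told apart, although the entering group has no hydrogen-bond acceptors and the leaving group has 2. The series also gains a second measured number, with an at least 7.3-fold lower number from compound 1 to compound 3 (0.86 log units; beyond the scatter) for 3,4-difluorobenzyl in place of (4-cyanophenyl)sulfonyl on an amine nitrogen in a ring. That step is only a bound, as compound 1 is reported as a limit and not a number: the limit of > 40000 nM in this assay, at which 1 of the 3 values shown sits.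

The compounds shown leave open whether the sulfonyl link or the nitrile accounts for that step, which a 4-cyanobenzyl group on the same nitrogen would separate. They also leave open whether an aromatic ring is needed there at all, as a cyclohexylmethyl group would test.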